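A methyl group added to compound 3

A few compounds are considered here, and "the series" means these few. Any claim that something is new, unique, unknown or untested is made for them only; others in the source may bear on it.

- Compound 1 `CC(C)(C)c1cc(OC(=O)c2ccco2)ccc1O` < 0.25 h
- Compound 2 `Cc1ccc(C(=O)Oc2ccc(O)c(C(C)(C)C)c2)cc1` < 0.25 h
- Compound 3 `CC(C)(C)c1cc(OC(=O)c2ccccc2)ccc1O` < 0.25 h

These three results come from an ADME assay on a cell-free system (serum) for metabolic stability (a higher number here means that the compound lasts longer, a lower number that the compound disappears faster), and share one feature (the limit of < 0.25 h in this assay, at which 3 of the 3 values shown sit). For compound 3, the result is a limit and not a number (< 0.25 h). Compound 4 `Cc1ccccc1C(=O)Oc1ccc(O)c(C(C)(C)C)c1` has methyl in place of hydrogen on an aromatic carbon, ortho to a large group (methyl in place of hydrogen on an aromatic carbon). The closest measured change swaps methyl and hydrogen too (a step that the two limits leave unreadable from compound 2 to compound 3). The two remaining steps offer no size either (a step that the two limits leave unreadable from compound 1 to compound 2; a step that the two limits leave unreadable from compound 1 to compound 3). The data therefore give no direction, and the half-life is expected to stay short. The expected result is a step that the limit leaves unreadable from compound 3 to compound 4 in this assay. For compound 4, the estimated half-life is 0.2 h, with an expected range from 0.08 h to 0.6 h.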

Compound 4, half-life: < 0.25 h
Compound 4 gave a limit, no number; the forecaster's own chance of this, stated with the estimate: 65%; the middle value does not contradict the limit.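

No step between compound 4 and compounds 1, 2 and 3 can be read in this assay, since all four results are limits and not numbers: the limit of < 0.25 h in this assay, at which 4 of the 4 values shown sit.

The compounds shown leave open how long each one actually lasts, and whether the added methyl changes that.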